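This account rests on a few compounds, and the source may have more. Where it says the series, first, only, none or still open, it means among the compounds named here.

Measured in a functional assay on MIA PaCa-2 cells (Homo sapiens) for cytotoxicity, read by WST assay, with a stated time of 48 h; a lower number here means a stronger inhibitor, a higher number a weaker inhibitor:
- Compound 1 `N#C/C(=C\c1cn(Cc2ccc(Cl)cc2)c2ccccc12)C(=O)c1c[nH]c2ccccc12`: > 50000 nM
- Compound 2 `COc1ccc(Cn2cc(/C=C(\C#N)C(=O)c3c[nH]c4cc(OC)ccc34)c3ccccc32)cc1`: > 50000 nM

Neither entry is a number. For compound 1, > 50000 nM is a limit of the assay. For compound 2, > 50000 nM is likewise a limit. Compound 2 therefore stands at the limit of > 50000 nM in this assay, at which 2 of the 2 values shown sit, and no exact potency can be read for it.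

Compound 3 `COc1ccc(Cn2cc(/C=C(\C#N)C(=O)c3c[nH]c4ccccc34)c3ccccc32)cc1` differs from compound 2 in one place: hydrogen in place of methoxy on an aromatic carbon. This is hydrogen in place of methoxy on an aromatic carbon, so that 6-methoxy-1H-indol-3-yl becomes 1H-indol-3-yl.

Within the data shown here, no measured pair in this assay shows a change of this kind, so the expectation rests only on the limit reached by both measured compounds. The expected step, a number no higher from compound 2 to compound 3 (the limit leaves the size open), is none beyond the scatter, and a further limit is the likeliest report. For compound 3 the expected value is 50000 nM, with an estimated range of 12000 nM to 100000 nM.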

Compound 3, half-maximal inhibitory concentration: > 50000 nM
Compound 3 ended at the assay's limit (the forecaster's own chance of this, stated with the estimate: 70%); the middle value lies on the limit itself.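

The result for compound 3 in this assay is a limit of the assay, so no step from compound 1 or compound 2 to compound 3 can be read: the limit of > 50000 nM in this assay, at which 3 of the 3 values shown sit.

The compounds shown leave open whether hydrogen in place of methoxy, or methoxy in place of chloro, on an aromatic carbon changes potency in this assay at all.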